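The compounds below may be only part of what the source reports. "The series", "measured", "known", "first", "only" and "open" are said of these compounds alone.

Measured compounds:
Compound 1 `CC(=O)NCc1cccc(Cn2nc(NS(=O)(=O)c3ccc(Cl)s3)c3c(C(C)O)cccc32)c1`: >= 208 ug/mL
Compound 2 `COc1cccc2c1c(NS(=O)(=O)c1ccc(Cl)s1)nn2Cc1cccc(CNC(=O)C2CCO2)c1`: 124 ug/mL

Within the data shown here, in a physicochemical assay for solubility, read by chemiluminescence, measured as kinetic solubility (a higher number here means a more soluble compound, a lower number a less soluble compound), compound 2 gives 124 ug/mL, the only plain number in the set. For compound 1 the reading in this assay is a limit of the assay, not a number; it sits at the limit of >= 208 ug/mL in this assay, at which 1 of the 2 values shown sits. Among the measured compounds shown here, no pair of measured compounds differs in a single place, so no measured step is available.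

Compound 3 `CN[C@H](C)C(=O)NCc1cccc(Cn2nc(NS(=O)(=O)c3ccc(Cl)s3)c3c(OC)cccc32)c1` has not yet been run in this assay. It differs from compound 2 by 1-(methylamino)ethyl in place of oxetan-2-yl on a carbonyl carbon. With only compound 2 as a direct anchor, the step is expected to run upward, of a size that may reach beyond the scatter but is not secured by any measured pair; the step from compound 2 to compound 3 is estimated at a 1.5-fold higher number from compound 2 to compound 3 (0.19 log units; within the scatter). For compound 3 the expected reading in this assay is 190 ug/mL, with a likely range from 90 ug/mL to 400 ug/mL, and a real chance that the assay returns only its limit.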

Compound 3, solubility: 191 ug/mL
Compound 3: middle estimate off by 1.0-fold (0.00 log units), on the low side; low and high end bracket the measured number.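

In this assay, the position on the carbonyl carbon now has its first measured step: a 1.5-fold higher number from compound 2 to compound 3 (0.19 log units; within the scatter). Oxetan-2-yl, a four-membered ring with no hydrogen-bond donor, and the open-chain 1-(methylamino)ethyl, with one donor and a defined stereocentre, therefore give readings that this pair cannot separate. Compound 1 carries a limit of the assay, not a number, and differs from the other compounds in more than one place, so it adds no comparison at this position: the limit of >= 208 ug/mL in this assay, at which 1 of the 3 values shown sits.

Going by these compounds, whether a dimethylamino-bearing chain, a longer aminoalkyl chain or a carboxylic acid on this carbonyl carbon would separate from oxetan-2-yl beyond the scatter remains open. Also open, on these data alone, is whether the mirror-image form of 1-(methylamino)ethyl would read the same.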